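The source may report more compounds than this note shows. Statements on the series, on what has been measured and on what is new or still open speak of the compounds shown alone.

In a functional assay on KBVIN cells (Homo sapiens) for antiproliferative activity, read by sulforhodamine B assay, with a stated time of 3 days (on this read-out higher numbers stand for an effect only at larger amounts of compound and lower numbers for an effect already at smaller amounts), compound 1 (`CCC1=C(O)c2c(oc(-c3ccc(C(C)C)cc3)cc2=O)C(CC)(CC)C1=O`) gives 1.08 uM, while compound 2 (`CCC1=C(O)c2c(oc(-c3ccc(OC)c(F)c3)cc2=O)C(CC)(CC)C1=O`) gives 0.1 uM, the lower of the two numbers. Compound 3 (`CCC1=C(O)c2c(oc(-c3ccc(OC)c(Cl)c3)cc2=O)C(CC)(CC)C1=O`) carries chloro in place of fluoro on an aromatic carbon. For the measured compounds named here, the only measured step, an 11-fold lower number from compound 1 to compound 2 (1.03 log units; beyond the scatter), is large, but it replaces the whole 4-isopropylphenyl group and does not test a single halogen exchange. Only a small change toward a higher number is therefore expected in this assay, the estimated step being a 1.5-fold higher number from compound 2 to compound 3 (0.18 log units; within the scatter). For compound 3 the estimate is 0.15 uM, with an expected range from 0.05 uM to 0.4 uM.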

Compound 3, concentration for half-maximal effect: 1.37 uM
Estimate against measurement, compound 3: 9.1-fold (0.96 log units) below; the measured number lies above the stated range.
By their numbers in this assay, from the lowest: compound 2; then compounds 1 and 3 (each within the scatter of the next).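

In this assay, the exchange of a single halogen on the aromatic carbon ortho to a methoxy group gives a 14-fold higher number from compound 2 to compound 3 (1.14 log units; beyond the scatter), so at this position fluoro and chloro are far from interchangeable, which the replacement of the whole aryl group could not show. With chloro in place, the advantage of compound 2 over compound 1 disappears: the comparison gives a 1.3-fold higher number from compound 1 to compound 3 (0.10 log units; within the scatter). Nothing measured here bears on the reason for this large step. On these data alone, whether hydrogen, bromo or methyl at this position would give numbers nearer compound 2 or compound 3 remains open. So does whether an ethoxy group in place of the methoxy group would alter the effect of the halogen exchange.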